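A few compounds are considered here, and "the series" means these few. Any claim that something is new, unique, unknown or untested is made for them only; others in the source may bear on it.

Compound 1 `Oc1ccc(-c2nc3cc(C(F)(F)F)ccc3[nH]2)cc1` gives 17000 nM
Compound 2 `O=[N+]([O-])c1ccc(-c2nc3cc(C(F)(F)F)ccc3[nH]2)cc1` gives 6000 nM
Compound 3 `O=[N+]([O-])c1ccc(-c2nc3cc(C(F)(F)F)ccc3[nH]2)c([N+](=O)[O-])c1` gives 9000 nM

In an ADME assay on MT4 cells (Homo sapiens) for cytotoxicity, read by MTT assay, with a stated time of 96 h (on this read-out higher numbers stand for lower toxicity in this test and lower numbers for higher toxicity in this test), compound 2 sits at the low end of the three numbers, level within the scatter with compound 3 and clearly apart from compound 1. Compound 4 `Fc1ccc(-c2nc3cc(C(F)(F)F)ccc3[nH]2)cc1` is still unmeasured and carries fluoro in place of nitro on an aromatic carbon in comparison with compound 2. Within the data shown here, two measured steps bear on this. Nitro in place of hydroxy on an aromatic carbon gave a 2.8-fold lower number from compound 1 to compound 2 (0.45 log units; beyond the scatter) and this modest step is the closer guide. Nitro in place of hydrogen gave a 1.5-fold higher number from compound 2 to compound 3 (0.18 log units; within the scatter) and so offers little guidance. With the nitro gone, part of that modest step is expected to be reversed. The expected change is a 1.8-fold higher number from compound 2 to compound 4 (0.26 log units; within the scatter) and it would be small and upward. Compound 4 is estimated at 11000 nM with an expected range of 5000 nM to 25000 nM in this read-out.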

Compound 4, half-maximal cytotoxic concentration: 22000 nM
Compound 4: middle estimate off by 2.0-fold (0.30 log units), on the low side; the measured number falls inside the stated range.
By their numbers in this assay, from the lowest: compounds 2, 3, 1 and 4 (each within the scatter of the next, the first and the last beyond it).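

In this assay, fluoro in place of nitro on this aromatic carbon gave a 3.7-fold higher number from compound 2 to compound 4 (0.56 log units; beyond the scatter), a step beyond the scatter, while fluoro in place of hydroxy gave a 1.3-fold higher number from compound 1 to compound 4 (0.11 log units; within the scatter), a step within it. At this position, then, compound 2 with its nitro stands apart from both compound 1 and compound 4, which do not separate from each other. Nothing measured here accounts for this gap. From the compounds shown here alone, whether an amine or a carboxylic acid at this position would fall with compound 2 or with the other two stays open. So does whether the nitro gap persists once the trifluoromethyl on the shared core is replaced.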